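The compounds below may be only part of what the source reports. "The series", "measured", "known", "first", "only" and "open" are said of these compounds alone.

Working notes on the series. The parent compound 1 `COc1cc(Cl)cc(-c2nn(-c3cccc(NC(=O)Nc4ccc(Cl)c(C(F)(F)F)c4)c3)cc2-c2ccncc2)c1` gives in a functional assay on HCT-15 cells (Homo sapiens) for inhibition, read by sulforhodamine B assay, with a stated time of 48 h, tested at 10 uM (on this read-out higher numbers stand for a weaker effect at the one concentration tested and lower numbers for a stronger effect), 7.28%. Compound 2 `COc1cc(Cl)cc(-c2nn(-c3cccc(NC(=O)c4cccc(C(F)(F)F)c4)c3)cc2-c2ccncc2)c1`, in which 3-(trifluoromethyl)phenyl replaces (4-chloro-3-(trifluoromethyl)phenyl)amino on the carbonyl carbon, gives in this assay 33.2%. Within the data shown here, on the two numbers so far compound 2 stands highest, that is weakest, the single step of a number 25.9 percentage points higher from compound 1 to compound 2 (beyond the scatter) lying beyond the scatter. Compound 3 `COc1cc(Cl)cc(-c2nn(-c3cccc(NC(=O)Nc4ccc(Cl)c(Cl)c4)c3)cc2-c2ccncc2)c1` is not yet measured in this assay. The change from compound 2 is (3,4-dichlorophenyl)amino in place of 3-(trifluoromethyl)phenyl on a carbonyl carbon. This returns an amino group to the carbonyl carbon, as in compound 1, with 3,4-dichlorophenyl rather than 4-chloro-3-(trifluoromethyl)phenyl on that nitrogen. Among the measured compounds shown here, the only step that bears on it is the one from compound 1 to compound 2, of modest size, and compound 3 is expected to walk most of it back, because compound 1 gives 7.28%. The step expected is therefore a number 20.2 percentage points lower from compound 2 to compound 3 (beyond the scatter), downward, beyond the scatter. On these data alone, whether the dichloro pattern matches the chloro-trifluoromethyl pattern is unknown, so the range is kept wide. Compound 3 is estimated at 13%, between 4% and 32%.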

Compound 3, a percentage reported as activity, at one concentration (the size of the read-out at that concentration, not a potency): 13.9%
Compound 3: the middle estimate sits 0.9 percentage points below what was measured; the range from low to high includes it.
By their numbers in this assay, from the lowest: compounds 1 and 3 (each within the scatter of the next); then compound 2.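

In this assay, the second compound carrying an aryl amino group on the carbonyl carbon also separates from compound 2, a number 19.3 percentage points lower from compound 2 to compound 3 (beyond the scatter), so among the three compounds shown both with that amino link lie beyond the scatter on the stronger side of compound 2, and none goes against this. Among these compounds, the chloro for trifluoromethyl change on an aromatic carbon, seen here for the first time, gives a number 6.6 percentage points higher from compound 1 to compound 3 (within the scatter), so on this read-out the two substitution patterns on the ring cannot be told apart at the one concentration tested. No measurement is available that explains either step.

The steps to and from compound 2 each change the amino link and the ring substituents together, so the part played by the amino nitrogen alone remains unseparated from that of the substituents. Also open, on these data alone, is how this position would read with a nitrile or a methoxy group on that ring, or with a cyclohexylamino group on the carbonyl carbon in place of the aryl amino group.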